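This account rests on a few compounds, and the source may have more. Where it says the series, first, only, none or still open, it means among the compounds named here.

In a functional assay on LOX IMVI cells (Homo sapiens) for cytotoxicity, read by MTT assay, with a stated time of 24 h (a higher number here means a weaker inhibitor, a lower number a stronger inhibitor), compound 1 `COc1ccc(S(=O)(=O)NCCCNc2nccc(-c3[nH]c(-c4ccccc4)nc3-c3ccc(F)c(OC)c3)n2)cc1` gives 6130 nM. This lies within the scatter of compound 2 `COc1cc(-c2nc(-c3ccccc3)[nH]c2-c2ccnc(NCCCNS(=O)(=O)c3ccccc3)n2)ccc1Cl` at 7470 nM and well under compound 3 `COc1cc(-c2nc(-c3ccccc3)[nH]c2-c2ccnc(NCCCNS(=O)(=O)c3ccc(Cl)cc3)n2)ccc1Cl` at 60900 nM. Compound 4 `COc1ccc(S(=O)(=O)NCCCNc2nccc(-c3[nH]c(-c4ccccc4)nc3-c3ccc(Cl)c(OC)c3)n2)cc1` differs from compound 1 by a single swap, chloro in place of fluoro on an aromatic carbon, so 4-fluoro-3-methoxyphenyl becomes 4-chloro-3-methoxyphenyl.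

Within the data shown here, no measured step makes this exact swap. The only one available, an 8.2-fold higher number from compound 2 to compound 3 (0.91 log units; beyond the scatter), puts chloro in place of hydrogen at a different place, so it bears on the question only loosely. Compound 2 already carries the 4-chloro-3-methoxyphenyl group, and its 7470 nM sits within the scatter of compound 1, although those two differ in more than one place. Compound 3 carries that group too, and its 60900 nM shows that numbers in this small set can climb. A small rise in this assay is therefore expected, held with little confidence. The estimated step is a 2.0-fold higher number from compound 1 to compound 4 (0.29 log units; within the scatter). For compound 4 the estimated value is 12000 nM, with an expected range from 4000 nM to 35000 nM.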

Compound 4, half-maximal inhibitory concentration: 1800 nM
For compound 4 the middle estimate is 6.7-fold (0.82 log units) above the measured one; the whole stated range lies above it.
By their numbers in this assay, from the lowest: compound 4; then compounds 1 and 2 (each within the scatter of the next); then compound 3.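

Replacing fluoro with chloro in the 4-fluoro-3-methoxyphenyl group gives a 3.4-fold lower number from compound 1 to compound 4 (0.53 log units; beyond the scatter) in this assay, so this position distinguishes between two halogens, and chloro here gives the lower number. At a second site, with 4-chloro-3-methoxyphenyl held constant, methoxy in place of hydrogen gives a 4.2-fold lower number from compound 2 to compound 4 (0.62 log units; beyond the scatter) and methoxy in place of chloro gives a 34-fold lower number from compound 3 to compound 4 (1.53 log units; beyond the scatter), so a para methoxy group there goes with the lowest number in this small set. No measurement shown here explains why either change moves the number. On these data alone, how bromo, methyl or an amine would read at the chloro position remains open. Also open, as far as these compounds go, is whether the gain from chloro over fluoro would persist with hydrogen at the second site or with a longer chain.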